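Phenoxyethyl for Phenoxymethyl: an Expected Efficacy Step

A few compounds are considered here, and "the series" means these few. Any claim that something is new, unique, unknown or untested is made for them only; others in the source may bear on it.

Compound 2 `O=C(O)c1cccc(OCc2ccc(OCc3c(-c4c(Cl)cccc4Cl)noc3C3CC3)nc2C(F)(F)F)c1` in an assay on isolated protein for agonist activity at Bile acid receptor (Homo sapiens), read by FRET (on this read-out lower numbers stand for smaller maximal responses and higher numbers for larger maximal responses), gives 98%. Among the measured compounds shown here, it is one of only two numbers so far; compound 1 `CC(Nc1ccc(C(=O)O)cc1)c1ccc(OCc2c(-c3c(Cl)cccc3Cl)noc2C2CC2)nc1C(F)(F)F` gives 99% in this assay, and the step of a number 1 percentage points lower from compound 1 to compound 2 (within the scatter). Compound 3 `CC(Oc1ccc(C(=O)O)cc1)c1ccc(OCc2c(-c3c(Cl)cccc3Cl)noc2C2CC2)nc1C(F)(F)F` differs from compound 2 by 1-(4-carboxyphenoxy)ethyl in place of (3-carboxyphenoxy)methyl on an aromatic carbon. For the measured compounds named here, the single measured step, which reworked the same position, stayed within the scatter, so no step beyond the scatter is expected in this assay; the estimated step is a number 1 percentage points lower from compound 2 to compound 3 (within the scatter). Compound 3 is therefore estimated at 97%, with a range from 85% to 106%.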

Compound 3, largest response reached (reported as efficacy), in percent of the reference or control that the assay uses: 89%
Beside the measured number, compound 3's estimate is 8 percentage points above it, and the stated range covers the measured number.
By their numbers in this assay, from the lowest: compounds 3, 2 and 1 (each within the scatter of the next).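

In this assay, 1-(4-carboxyphenoxy)ethyl in place of (3-carboxyphenoxy)methyl gives a number 9 percentage points lower from compound 2 to compound 3 (within the scatter) and so adds a second reworking of this position. Swapping only the link, with 4-carboxyphenoxy in place of (4-carboxyphenyl)amino, gives a number 10 percentage points lower from compound 1 to compound 3 (within the scatter) and shows that this exchange also stays inside the usual scatter. Nothing measured here explains these steps.

Going by these compounds, the step from compound 2 to compound 3 alters the side group in more than one way, so the share of each alteration stays open. Side groups such as (4-carboxyphenoxy)methyl or 1-(3-carboxyphenoxy)ethyl would separate them, and a tetrazole in place of the carboxylic acid remains an open question.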